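This account rests on a few compounds, and the source may have more. Where it says the series, first, only, none or still open, it means among the compounds named here.

Compound 1 `COc1ccccc1/C=C/C(=O)c1ccc(OCCn2cc(CN3C(=O)/C=C/C(C)(C)C/C=C(\C)CC/C=C/3C)nn2)cc1O` and compound 3 `COc1ccccc1/C=C/C(=O)c1ccc(OCCCN2C(=O)/C=C/C(C)(C)C/C=C(\C)CC/C=C/2C)cc1` carry the same trans-enone and triene lactam ends but differ in the linker; the difference between the two cores is not broken down here. In a functional assay on MCF7 cells (Homo sapiens) for antiproliferative activity (a higher number here means a weaker inhibitor, a lower number a stronger inhibitor), compound 1 gives 1.17 ug/mL and compound 3 gives 1.56 ug/mL, two values that stand within the scatter of each other. Compound 2 `COc1cc(/C=C/C(=O)c2ccc(OCCn3cc(CN4C(=O)/C=C/C(C)(C)C/C=C(\C)CC/C=C/4C)nn3)cc2O)cc(OC)c1OC` differs from compound 1 in one place: 3,4,5-trimethoxyphenyl in place of 2-methoxyphenyl on a double-bonded chain carbon bound to a double-bonded chain carbon With that change the step is a 2.4-fold higher number from compound 1 to compound 2 (0.38 log units; beyond the scatter), and in this assay compound 2 gives 2.78 ug/mL. For the measured compounds named here, compound 4 `COc1cc(/C=C/C(=O)c2ccc(OCCCN3C(=O)/C=C/C(C)(C)C/C=C(\C)CC/C=C/3C)cc2)cc(OC)c1OC` awaits measurement; it differs from compound 3 by the same change at the same place: 3,4,5-trimethoxyphenyl in place of 2-methoxyphenyl on a double-bonded chain carbon bound to a double-bonded chain carbon The step from compound 3 to compound 4 is expected to go in the same direction and to be of about the same modest size, because the single precedent for this change on the core of compound 1 is a 2.4-fold higher number from compound 1 to compound 2 (0.38 log units; beyond the scatter). Set beside that earlier step, the expected step is a 2.3-fold higher number from compound 3 to compound 4 (0.36 log units; beyond the scatter). Going by the values given here, for compound 4 in this assay the estimate is 3.6 ug/mL, with a range from 1.8 ug/mL to 7 ug/mL, the width reflecting that only one precedent exists.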

Compound 4, half-maximal inhibitory concentration: 0.58 ug/mL
Estimate against measurement, compound 4: 6.2-fold (0.79 log units) above; the measured number lies below the stated range.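

In this assay, 3,4,5-trimethoxyphenyl in place of 2-methoxyphenyl gives a 2.7-fold lower number from compound 3 to compound 4 (0.43 log units; beyond the scatter), so on this core the change goes with stronger inhibition. The direction of the change does not carry from one core to the other: the same change on two cores in this assay, a 2.4-fold higher number (0.38 log units; beyond the scatter) from compound 1 to compound 2 and a 2.7-fold lower number (0.43 log units; beyond the scatter) from compound 3 to compound 4, 6.4-fold (0.81 log units) apart, beyond the scatter of two such steps. The two pairs show that the result of this change in the series cannot be assumed from one core to another, but with a single pair per core they do not show which of the differences between the cores accounts for the reversal, and they say nothing about any further core.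

The compounds shown leave open whether an unsubstituted phenyl or a 3,4-dimethoxyphenyl in the same place would follow the pattern of the core of compound 1 or that of the core of compound 3. Also open, on these data alone, is whether a longer chain in the linker of compound 4 would keep its stronger inhibition.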